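A few compounds are considered here, and "the series" means these few. Any claim that something is new, unique, unknown or untested is made for them only; others in the source may bear on it.

Measured compounds:
compound 1 `CCCCN(C)c1nc(C(C)(C)C)ccc1CNC(=O)C(C)c1ccc(NS(C)(=O)=O)c(F)c1` — 1.2 nM
compound 2 `CCC1CCN(c2nc(C(C)(C)C)ccc2CNC(=O)C(C)c2ccc(NS(C)(=O)=O)c(F)c2)CC1` — 0.1 nM
compound 3 `CCOc1nc(C(C)(C)C)ccc1CNC(=O)C(C)c1ccc(NS(C)(=O)=O)c(F)c1` — 14.8 nM

Of the three compounds measured in an assay on cells for antagonist activity at transient receptor potential cation channel subfamily V member 1 (Homo sapiens), read by FLIPR and calcium flux, with a stated time of 6 min (a lower number here means a stronger inhibitor, a higher number a weaker inhibitor), compound 3 gives the highest number, at 14.8 nM. One step up to it is a 12-fold higher number from compound 1 to compound 3 (1.09 log units; beyond the scatter), and the other is a 150-fold higher number from compound 2 to compound 3 (2.17 log units; beyond the scatter); both lie beyond the scatter, so compound 3 is the weakest of the three.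

Compound 4 `CCCCCCOc1nc(C(C)(C)C)ccc1CNC(=O)C(C)c1ccc(NS(C)(=O)=O)c(F)c1` differs from compound 3 by butyl in place of hydrogen on a saturated chain carbon, two bonds along the chain from an oxygen on an aromatic ring. Among the measured compounds shown here, no measured step extends a chain at this position; the two steps that bear on it, a 12-fold higher number from compound 1 to compound 3 (1.09 log units; beyond the scatter) and a 150-fold higher number from compound 2 to compound 3 (2.17 log units; beyond the scatter), both replace the whole group and both show ethoxy as the weakest variant. Whether a longer alkoxy chain follows the same trend is not settled by these data, so only a moderate step is expected.

For compound 4 the expected step is a 3.0-fold lower number from compound 3 to compound 4 (0.47 log units; beyond the scatter), giving an estimate of 5 nM with a range from 1.5 nM to 20 nM.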

Compound 4, inhibition constant: 2.7 nM
Compound 4: the middle estimate sits 1.9-fold (0.27 log units) above what was measured; low and high end bracket the measured number.
By their numbers in this assay, from the lowest: compound 2; then compound 1; then compound 4; then compound 3.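

In this assay, among the compounds shown here, extending ethoxy to hexyloxy gives a 5.5-fold lower number from compound 3 to compound 4 (0.74 log units; beyond the scatter), the first sign that the length of the chain on this oxygen matters, since the earlier steps only replaced the whole group. The longer chain does not match either amine, with a 2.3-fold higher number from compound 1 to compound 4 (0.35 log units; beyond the scatter) and a 27-fold higher number from compound 2 to compound 4 (1.43 log units; beyond the scatter), and the second of these gaps is much the wider. Nothing available gives a reason for these steps.

With only ethoxy and hexyloxy in hand, the compounds shown do not tell whether the number falls steadily with length, levels off or turns back, which butoxy or octyloxy would help to settle. They also leave open whether a branched chain, or a hexyloxy chain ending in a hydroxyl or an amine, would behave as hexyloxy does.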